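A few compounds are considered here, and "the series" means these few. Any claim that something is new, unique, unknown or untested is made for them only; others in the source may bear on it.

Compound 1 `C=CC1=C(C(=O)NCc2ccc(Cl)cc2)C(c2ccc(F)cc2)OC1` was tested in a functional assay on A549 cells (Homo sapiens) for cytotoxicity, read by MTT assay, with a stated time of 24 h; on this read-out lower numbers stand for stronger inhibition and higher numbers for weaker inhibition. In this assay compound 1 gives > 100000 nM, which is a limit of the assay and not a number. Compound 2 `C=CC1=C(C(=O)NCCCCC)C(c2ccc(F)cc2)OC1` carries butyl in place of 4-chlorophenyl on a saturated chain carbon bound to an amide-type nitrogen. In this assay compound 2 gives > 100000 nM, likewise a limit. The step that the two limits leave unreadable from compound 1 to compound 2 therefore cannot be read. Compound 3 `C=CC1=C(C(=O)NCc2ccc(Cl)cc2)C(c2ccc(OC)cc2)OC1` differs from compound 1 in its core by methoxy in place of fluoro on an aromatic carbon. In this assay compound 3 gives > 100000 nM, again a limit, so a step that the two limits leave unreadable from compound 1 to compound 3 is unreadable as well. Compound 4 `C=CC1=C(C(=O)NCCCCC)C(c2ccc(OC)cc2)OC1` is not yet measured; it differs from compound 3 by butyl in place of 4-chlorophenyl on a saturated chain carbon bound to an amide-type nitrogen, the same change that separates compound 1 and compound 2. Among the measured compounds shown here, because the limit of > 100000 nM in this assay, at which 3 of the 3 values shown sit, holds every value so far, the step that the limit leaves unreadable from compound 3 to compound 4 is expected to remain hidden behind the limit, an expectation resting on a step that the two limits leave unreadable from compound 1 to compound 2. For compound 4 in this assay the estimate is 150000 nM, most likely reported once more as a limit.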

Compound 4, half-maximal inhibitory concentration: 36500 nM
The estimate for compound 4 lay 4.1-fold (0.61 log units) above the measured number; measured number outside the range, below it.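

On the core of compound 3, butyl in place of 4-chlorophenyl gives an at least 2.7-fold lower number from compound 3 to compound 4 (0.43 log units; beyond the scatter) in this assay, and with butyl held, methoxy in place of fluoro gives an at least 2.7-fold lower number from compound 2 to compound 4 (0.43 log units; beyond the scatter). As far as these compounds go, the same butyl change on the core of compound 1 and the methoxy change with 4-chlorophenyl retained cannot be read, so the data do not show whether either change carries from one core to another: the limit of > 100000 nM in this assay, at which 3 of the 4 values shown sit. The two readable steps give only minimum sizes, and the true sizes remain unknown.

The compounds shown leave open whether a longer chain or an amine in place of butyl would give a lower number in this assay. They also leave open whether any other group in place of methoxy would retain a measurable number.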